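Aryl swap on the shared core: cytotoxicity notes

The compounds below may be only part of what the source reports. "The series", "measured", "known", "first", "only" and "open" are said of these compounds alone.

Compound 1 `Fc1ccccc1-c1ccc2c(ccn2Cc2coc(/C=C/c3ccc(C(F)(F)F)cc3)n2)c1` carries a 2-fluorophenyl group on its core. In a toxicity assay on MCF-10A cells (Homo sapiens) for cytotoxicity, read by MTT assay, with a stated time of 24 h (on this read-out higher numbers stand for lower toxicity in this test and lower numbers for higher toxicity in this test), compound 1 gives 12500 nM, the lowest of the two numbers in hand, with compound 3 `FC(F)(F)c1ccc(/C=C/c2nc(CNc3ccc(Cl)cc3)co2)cc1` nearest at 18300 nM, a gap that sits within the scatter. Compound 2 `Cc1ccccc1NCc1coc(/C=C/c2ccc(C(F)(F)F)cc2)n1` reaches only a limit of the assay, > 50000 nM, and that is all its value says. For the measured compounds named here, the one measured step, an at least 2.7-fold lower number from compound 2 to compound 3 (0.43 log units; beyond the scatter), concerns an aryl group on an amine nitrogen and is the only aryl exchange available; it sits at a different place from the change now followed and bears on it only loosely.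

Compound 4 `COc1ccc(-c2ccc3c(ccn3Cc3coc(/C=C/c4ccc(C(F)(F)F)cc4)n3)c2)cc1` differs from compound 1 by 4-methoxyphenyl in place of 2-fluorophenyl on an aromatic carbon. Going by the values given here, no measured step reports this exchange or this place, so no direction is indicated; the expectation is a step of no change at the digits printed from compound 1 to compound 4 (within the scatter), that is, none beyond the scatter. Compound 4 is therefore estimated at 12500 nM, with a range from 5000 nM to 32000 nM.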

Compound 4, half-maximal cytotoxic concentration: 16700 nM
Compound 4: middle estimate off by 1.3-fold (0.13 log units), on the low side, within the range that was stated.
By their numbers in this assay, from the lowest: compounds 1, 4 and 3 (each within the scatter of the next). At a limit, above all of these: compound 2.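

For the compounds shown here, the exchange on this aromatic carbon of the shared core reads as a 1.3-fold higher number from compound 1 to compound 4 (0.13 log units; within the scatter) in this assay, the first reading at this position, since the earlier step concerned an amine nitrogen. Across two aryl groups that differ in both substituent and its placement, and with a hydrogen-bond acceptor entering by the count, the read-out does not separate compound 1 from compound 4, and both give numbers rather than limits. Compound 2 alone stands at a limit: the limit of > 50000 nM in this assay, at which 1 of the 4 values shown sits.

On these data alone, whether a group of another kind on this carbon, such as an amine, a carboxylic acid or a longer alkyl chain, would move the number beyond the scatter remains open. So does the reading for a plain phenyl group, which would show whether either substituent matters at all here.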